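Hydroxy in place of ethyl on the chain of compound 1

The compounds below may be only part of what the source reports. "The series", "measured", "known", "first", "only" and "open" are said of these compounds alone.

Measured so far:
- compound 1 `CCCCC#Cc1cc(C(=O)OCC)nc2ccc(OC)cc12` at 7200 nM
- compound 2 `CCOC(=O)c1cc([Se]c2ccccc2)c2cc(Cl)ccc2n1` at 47100 nM
- compound 3 `COc1ccc2nc(-c3c(C)cccc3C)cc([Se]c3ccccc3)c2c1` at 37300 nM

All three values come from a functional assay on SK-MEL-147 cells (Homo sapiens) for cytotoxicity, read by MTT assay, with a stated time of 24 h (on this read-out higher numbers stand for an effect only at larger amounts of compound and lower numbers for an effect already at smaller amounts), and compound 1 holds the lowest number, with compound 3 and compound 2 both beyond the scatter above it. Compound 4 `CCOC(=O)c1cc(C#CCCO)c2cc(OC)ccc2n1` has not been measured. It keeps the core of compound 1 and differs only at the chain end, with hydroxy in place of ethyl on a saturated chain carbon, two bonds along the chain from a triple-bonded carbon. The counted difference is hydroxy in place of ethyl on a saturated chain carbon, two bonds along the chain from a triple-bonded carbon and it turns hex-1-yn-1-yl into 4-hydroxybut-1-yn-1-yl.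

Within the data shown here, no measured pair shows this change, so the expectation rests on little. Compound 1 at 7200 nM already sits lowest of the three, which leaves more room for a rise than for a fall. The expected step of a 1.8-fold higher number from compound 1 to compound 4 (0.26 log units; within the scatter) points to a higher number in this assay and is not clearly beyond the scatter. For compound 4 the estimated value is 13000 nM with an expected range from 4500 nM to 40000 nM as the working figures.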

Compound 4, half-maximal effective concentration: > 150000 nM
Compound 4 ended at the assay's limit; the forecaster's own chance of this, stated with the estimate: 5%; middle value at least 11-fold (1.06 log units) from the limit.
By their numbers in this assay, from the lowest: compound 1; then compounds 3 and 2 (each within the scatter of the next). At a limit, above all of these: compound 4.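

In this assay compound 4 gives > 150000 nM, which is a limit of the assay and not a number: the limit of > 150000 nM in this assay, at which 1 of the 4 values shown sits. Hydroxy in place of ethyl on a saturated chain carbon, two bonds along the chain from a triple-bonded carbon, gives an at least 20-fold higher number from compound 1 to compound 4 (1.31 log units; beyond the scatter), so the read-out in this assay responds strongly to a change at this chain end. The earlier compounds shown here offered no pair differing in one place, and this position had no reading until now.

The step joins two things, ethyl leaving and hydroxy entering, and the compounds shown do not separate them. Going by these compounds, an amine or a carboxylic acid at the same chain end, or a longer chain carrying the hydroxy, remains open, as does how far the loss of activity extends beyond this single pair.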